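Quinoxaline-diamine series: cytotoxicity on UO-31 cells, limit values only

A few compounds are considered here, and "the series" means these few. Any claim that something is new, unique, unknown or untested is made for them only; others in the source may bear on it.

Measured so far:
- compound 1 `CCOC(=O)[C@H](CCC(=O)O)NC(=O)c1ccc(CNc2nc3cc(N)cc(N)c3nc2-c2ccccc2)cc1`: < 100000 nM
- compound 2 `Nc1cc(N)c2nc(-c3ccccc3)c(NCc3ccc(Cl)c(Cl)c3)nc2c1`: < 100000 nM
- compound 3 `CCOC(=O)[C@H](CCC(=O)O)NC(=O)c1ccc(Sc2nc3cc(N)cc(N)c3nc2-c2ccccc2)cc1`: < 100000 nM

In a functional assay on UO-31 cells (Homo sapiens) for inhibition, read by sulforhodamine B assay, with a stated time of 48 h (a lower number here means that less compound is tolerated, a higher number that more compound is tolerated), compound 2 gives < 100000 nM, a limit of the assay and not a number. The two other measured compounds likewise return only limits in this assay, so compound 2 cannot be placed above or below them; the shared picture is the limit of < 100000 nM in this assay, at which 3 of the 3 values shown sit.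

Compound 4 `Nc1cc(N)c2nc(-c3ccccc3)c(NCc3ccc(F)cc3)nc2c1` is the next member to be run. It differs from compound 2 in one place: 4-fluorophenyl in place of 3,4-dichlorophenyl on a saturated chain carbon bound to a nitrogen on an aromatic ring.

For the measured compounds named here, no measured step exists anywhere, so nothing within it tells how large a change of this kind can be. The expectation is that the step that the limit leaves unreadable from compound 2 to compound 4 stays within the usual scatter, in no particular direction. Compound 4 is accordingly expected to give 60000 nM in this assay, most likely again as a limit, within 15000 nM to 100000 nM.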

Compound 4, concentration lethal to 50% of the cells: < 100000 nM
Compound 4: a limit, no number (the forecaster's own chance of this, stated with the estimate: 75%); the middle value does not contradict the limit.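

Compound 2 and compound 4 both return only limits in this assay, so no step can be read for 4-fluorophenyl in place of 3,4-dichlorophenyl: the limit of < 100000 nM in this assay, at which 4 of the 4 values shown sit.

The compounds shown leave open where any of them stands as a number in this assay and how large a change of group can be.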